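The compounds below may be only part of what the source reports. "The series", "measured", "known", "first", "only" and "open" are said of these compounds alone.

Working notes on the urea series, solubility.

Compound 1 `N#Cc1ccc(NC(=O)Nc2ccc(F)c(C(F)(F)F)c2)cc1` was measured in a physicochemical assay for solubility, read by nephelometry, in phosphate buffer, measured as kinetic solubility, at pH 6.5; on this read-out lower numbers stand for lower solubility and higher numbers for higher solubility. For compound 1 only a limit of the assay is reported, < 1.6 ug/mL. Compound 2 `O=C(Nc1ccc(F)c(C(F)(F)F)c1)Nc1cnccn1` is a second member of the series. Compound 2 likewise gives only a limit in this assay, < 1.6 ug/mL. For the measured compounds named here, compound 3 `O=C(Nc1ccnc(C(F)(F)F)c1)Nc1ccnc(C(F)(F)F)c1` is the one member with a number: in this assay compound 3 gives 12.5 ug/mL. Compound 1 therefore stands at the floor of what this assay reports, and the same floor is shared by compound 2, so that (the limit of < 1.6 ug/mL in this assay, at which 2 of the 3 values shown sit); compound 3 alone stands above it.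

The next compound, compound 4 `O=C(Nc1ccc(C(=O)O)cc1)Nc1ccc(F)c(C(F)(F)F)c1`, has not yet been measured in this assay. It differs from compound 1 in one place: carboxy in place of cyano on an aromatic carbon. Going by the values given here, no measured pair carries this change, so its effect is not known from the data here; a rise is expected, since compound 1 sits at the limit < 1.6 ug/mL and cannot fall further in the read-out, while the counted change adds a hydrogen-bond donor and a heavier group. The step from compound 1 to compound 4 is expected to be an at least 15-fold higher number from compound 1 to compound 4 (1.19 log units; beyond the scatter), beyond the scatter. For compound 4 the estimate in this assay is 25 ug/mL, with a range from 5 ug/mL to 120 ug/mL.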

Compound 4, solubility: 12.5 ug/mL
Estimate against measurement, compound 4: 2.0-fold (0.30 log units) above; measured number inside the range.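

Carboxy in place of cyano on an aromatic carbon, para to a large group, is the first change in the series with a readable step in this assay, and it gives an at least 7.8-fold higher number from compound 1 to compound 4 (0.89 log units; beyond the scatter). For the compounds shown here, this shows that the part of the core shared by compound 1 and compound 4 does not by itself hold the read-out at the floor, which the earlier compounds could not show, as no measured pair linked them. Only a lower bound on the step can be given, and its true size stays unknown, because its starting point is a limit of the assay and not a number: the limit of < 1.6 ug/mL in this assay, at which 2 of the 4 values shown sit.

As far as these compounds go, what stays open is whether this rise is particular to carboxy, or whether a primary amide, an amine or a methyl ester at the same position would read in the same way. The compounds shown also do not tell whether the same change would hold on a core with a different partner on the other side of the urea.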